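This account rests on a few compounds, and the source may have more. Where it says the series, first, only, none or still open, it means among the compounds named here.

Compound 2 `O=C(Nc1nc2ccc(-c3cccc(CO)c3)cc2s1)c1ccccc1Br` is one of two measured analogues built on the same core. In a functional assay on A549 cells (Homo sapiens) for inhibition, read by MTT assay, with a stated time of 48 h (a higher number here means a weaker inhibitor, a lower number a stronger inhibitor), compound 2 gives 57500 nM, and compound 1 `O=C(Nc1nc2ccc(-c3cccc(CO)c3)cc2s1)c1ccc(F)cc1Cl` gives 71400 nM; the step of a 1.2-fold lower number from compound 1 to compound 2 (0.09 log units; within the scatter) lies within the scatter, so the two numbers cannot be told apart. Compound 3 `Cc1cc(C)c(C(=O)Nc2nc3ccc(-c4cccc(CO)c4)cc3s2)o1` differs from compound 2 by 3,5-dimethylfuran-2-yl in place of 2-bromophenyl on a carbonyl carbon. Among the compounds with values here, the only measured step, a 1.2-fold lower number from compound 1 to compound 2 (0.09 log units; within the scatter), also exchanged the group on the carbonyl carbon and showed nothing beyond the scatter, so the expected step is a 1.0-fold higher number from compound 2 to compound 3 (0.02 log units; within the scatter), no change beyond the scatter in this assay. Compound 3 is therefore estimated at 60000 nM, with a likely range from 20000 nM to 180000 nM.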

Compound 3, half-maximal inhibitory concentration: 63200 nM
Beside the measured number, compound 3's estimate is 1.1-fold (0.02 log units) below it, within the range that was stated.
By their numbers in this assay, from the lowest: compounds 2, 3 and 1 (each within the scatter of the next).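

In this assay, the group on the carbonyl carbon changes more deeply than before: a five-membered aromatic ring with one oxygen, carrying one hydrogen-bond acceptor, replaces a six-membered aromatic ring of carbon only. Even so, the result is a 1.1-fold higher number from compound 2 to compound 3 (0.04 log units; within the scatter) and a 1.1-fold lower number from compound 1 to compound 3 (0.05 log units; within the scatter), so this change of ring type leaves no readable difference at this position. No available evidence bears on this result. Still open, on these data alone, is whether a carboxylic acid or an aminomethyl group on that ring would separate from these three compounds.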